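This account rests on a few compounds, and the source may have more. Where it says the series, first, only, none or still open, it means among the compounds named here.

In an ADME assay on MT4 cells (Homo sapiens) for cytotoxicity (a lower number here means that less compound is tolerated, a higher number that more compound is tolerated), compound 1 `Cc1cc(C)cc(Cn2c(SCC(=O)Nc3ccccc3Cl)nc3ccccc32)c1` gives 111000 nM. Compound 2 `Cc1cc(C)cc(Cn2c(SCC(=O)Nc3ccccc3Br)nc3ccccc32)c1` gives only a limit of the assay, >= 143000 nM. Compound 3 `Cc1cc(C)cc(Cn2c(SCC(=O)Nc3ccc(C)cc3Cl)nc3ccccc32)c1` gives 49200 nM, the lower of the two actual numbers, and so stands at the low end of this small set. The next compound, compound 4 `COC(=O)c1ccc(NC(=O)CSc2nc3ccccc3n2Cc2cc(C)cc(C)c2)c(Cl)c1`, differs from it as follows: methoxycarbonyl in place of methyl on an aromatic carbon. In words, this is methoxycarbonyl in place of methyl on an aromatic carbon, para to a large group. Within the data shown here, no measured step places methoxycarbonyl on this carbon, so the support is indirect. The closest evidence is a 2.3-fold lower number from compound 1 to compound 3 (0.35 log units; beyond the scatter), where methyl replaces hydrogen at the same place. The step of an at least 2.9-fold lower number from compound 2 to compound 3 (0.46 log units; beyond the scatter) combines that change with another one, while an at least 1.2-fold higher number from compound 1 to compound 2 (0.11 log units; that floor lies within the scatter) concerns only the halogen. These steps are modest, and they give no firm direction for the new group, so no step beyond the scatter is expected. The estimated change is a 1.2-fold higher number from compound 3 to compound 4 (0.09 log units; within the scatter). For compound 4 the expected value is 60000 nM, with an estimated range of 22000 nM to 150000 nM.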

Compound 4, half-maximal cytotoxic concentration: 191000 nM
Beside the measured number, compound 4's estimate is 3.2-fold (0.50 log units) below it; the measured number lies above the stated range.
By their numbers in this assay, from the lowest: compound 3; then compounds 1 and 4 (each within the scatter of the next).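

On this carbon, para to a large group, the size of the substituent alone does not set the direction in this assay: with methoxycarbonyl in place of methyl there is a 3.9-fold higher number from compound 3 to compound 4 (0.59 log units; beyond the scatter). Measured against hydrogen at the same place, methoxycarbonyl gives a 1.7-fold higher number from compound 1 to compound 4 (0.24 log units; within the scatter), so the drop seen with methyl, a 2.3-fold lower number from compound 1 to compound 3 (0.35 log units; beyond the scatter), does not carry over to this larger group. The step from compound 2 to compound 4 cannot be read, because compound 2 gives only a limit: the limit of >= 143000 nM in this assay, at which 1 of the 4 values shown sits.

From the compounds shown here alone, what a carboxylic acid or a nitrile on this carbon would give in this assay stays open. Also open, going by these compounds, is whether methoxycarbonyl acts the same way with bromo in place of chloro on the ring.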